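Pyridin-4-yloxy replaces the aminopyrimidinyloxy head group

The source may hold more compounds than are shown below. What is called first, only, known or untested is meant among the compounds shown, and "the series" means these compounds.

Measured compounds:
compound 1, `CCNc1cc(Oc2ccc(NC(=O)Nc3cccc(C(F)(F)F)c3)cc2)ncn1`, 25 nM
compound 2, `CNc1cc(Oc2ccc(NC(=O)Nc3cccc(C(F)(F)F)c3)c(F)c2F)ncn1`, 20 nM
compound 3, `CNc1cc(Oc2ccc(NC(=O)Nc3cccc(C(F)(F)F)c3)c(F)c2)ncn1`, 63 nM

Three diaryl ureas have been measured in an assay on isolated protein for inhibition of serine/threonine-protein kinase TNNI3K (Homo sapiens); on this read-out lower numbers stand for stronger inhibition and higher numbers for weaker inhibition. Compound 1 gives 25 nM and stands second highest of the three numbers; its nearest neighbour is compound 2 at 20 nM, which lies within the scatter of compound 1, while compound 3 at 63 nM sits furthest away, beyond the scatter. Among the measured compounds shown here, the one single-point step among the measured compounds, a 3.2-fold higher number from compound 2 to compound 3 (0.50 log units; beyond the scatter), concerns a fluoro on the central aromatic ring and says nothing about the head group attached through the ether oxygen.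

Compound 4, `O=C(Nc1ccc(Oc2ccncc2)cc1)Nc1cccc(C(F)(F)F)c1`, is reached from compound 1 by pyridin-4-yl in place of 6-(ethylamino)pyrimidin-4-yl on an oxygen on an aromatic ring. For the measured compounds named here, no measured pair changes this part of the molecule, so the expectation rests on the structural difference alone: a larger fragment with a hydrogen-bond donor and two further acceptors gives way to a smaller one with none of these, and the loss is expected to register as weaker inhibition. Compound 4 is expected to show a 12-fold higher number from compound 1 to compound 4 (1.08 log units; beyond the scatter) in this assay. Compound 4 is therefore estimated at 300 nM, with a range from 60 nM to 2000 nM.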

Compound 4, half-maximal inhibitory concentration: 50 nM
Compound 4: middle estimate off by 6.0-fold (0.78 log units), on the high side; measured number below the stated range.
By their numbers in this assay, from the lowest: compounds 2, 1, 4 and 3 (each within the scatter of the next, the first and the last beyond it).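

In this assay the exchange of 6-(ethylamino)pyrimidin-4-yl for pyridin-4-yl on the oxygen gives a 2.0-fold higher number from compound 1 to compound 4 (0.30 log units; within the scatter) and so leaves no readable difference between the two head groups, even though the group that enters has fewer heavy atoms, no hydrogen-bond donor and fewer hydrogen-bond acceptors than the group that leaves. Among the compounds shown here, this is the first reading at this position, since the only earlier step concerned a fluoro on the central aromatic ring, and it shows that, on the core of compound 1, neither the ethylamino group nor the second ring nitrogen of the pyrimidine is needed to keep the number within the scatter. Nothing in the material available accounts for this tolerance.

The compounds shown leave open whether the head groups stay equivalent on the fluorinated rings of compound 2 and compound 3, where the single fluoro step was beyond the scatter. They also leave open how the unsubstituted pyrimidin-4-yl, pyridin-3-yl or a pyridin-4-yl carrying a methylamino group would read at the same oxygen.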